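A few compounds are considered here, and "the series" means these few. Any claim that something is new, unique, unknown or untested is made for them only; others in the source may bear on it.

Measured so far:
- compound 1, `CCNCc1ccc(N/C(=C2\C(=O)Nc3cc(C(=O)N(C)CC)ccc32)c2ccccc2)cc1`, 88%
- compound 2, `CN(C)C(=O)c1ccc2c(c1)/C(=C(/Nc1ccc(CN3CCCCC3)cc1)c1ccccc1)C(=O)N2`, 19%
- compound 3, `CCNC(=O)c1ccc2c(c1)NC(=O)/C2=C(\Nc1ccc(CN(C)C)cc1)c1ccccc1`, 102%

The three measured compounds share a core and were tested in an assay on isolated protein for inhibition of lymphokine-activated killer T-cell-originated protein kinase (Homo sapiens), tested at 1 uM; on this read-out higher numbers stand for more inhibition at the one concentration tested (going by the name of the read-out) and lower numbers for less inhibition. Compound 3 gives 102% and compound 1 gives 88%, and in this assay compound 2 gives 19%. Compound 2 thus stands lowest of the three numbers: its nearest neighbour is compound 1, whose number is higher by more than the usual scatter, and compound 3 lies further still above it.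

Compound 4, `O=C1Nc2ccccc2/C1=C(/Nc1ccc(CN2CCCCC2)cc1)c1ccccc1`, has not yet been measured in this assay. It differs from compound 2 in one place: hydrogen in place of dimethylcarbamoyl on an aromatic carbon. Among the compounds with values here, the two other measured compounds differ from compound 2 in more than one place, so no single-change step can be drawn from them, and the effect of taking away the dimethylcarbamoyl has to be guessed.

Since compound 2 gives 19%, there is little room to fall further, and a small step downward or none beyond the scatter is expected in this assay. The step from compound 2 to compound 4 is estimated at a number 5 percentage points lower from compound 2 to compound 4 (within the scatter). Compound 4 is expected to give 14% in this assay, within a range from 0% to 40%.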

Compound 4, a percentage reported as inhibition, at one concentration (the size of the read-out at that concentration, not a potency): 5%
For compound 4 the middle estimate is 9 percentage points above the measured one; measured number inside the range.
By their numbers in this assay, from the lowest: compound 4; then compound 2; then compound 1; then compound 3.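

In this assay the exchange of dimethylcarbamoyl for hydrogen on this aromatic carbon gives a number 14 percentage points lower from compound 2 to compound 4 (beyond the scatter) as the first single-change step available, so this position can now be read on its own. Losing the group leaves less inhibition at the one concentration tested, but the step is modest and starts from a low number, with compound 2 at 19% already, so it cannot show how much the same exchange would cost on a compound with more inhibition. No measurement shown here explains why the number falls.

As far as these compounds go, it remains open whether the full dimethylcarbamoyl is needed on this carbon, or whether a carboxylic acid, a methyl ester, an unsubstituted carboxamide or a simple amine would serve as well. Within the data shown here, also open is whether removing the amide group would have a similar effect with the piperidine of compound 2 and compound 4 replaced by a smaller amine such as dimethylamine, since no single-change step yet isolates that part of the molecule.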